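A few compounds are considered here, and "the series" means these few. Any claim that something is new, unique, unknown or untested is made for them only; others in the source may bear on it.

Compound 1 `O=C(Nc1ccc(Cl)c(-c2nnc3c(Cl)cccn23)c1)c1ccc(C(F)(F)F)cc1Cl` and compound 2 `O=C(Nc1ccc(Cl)c(-c2nnc3c(Cl)cccn23)c1)c1ccc(Cl)cc1` share one core and differ only in the aromatic group on the carbonyl carbon. In a functional assay on MDA-MB-468 cells (Homo sapiens) for antiproliferative activity, read by MTT assay, with a stated time of 72 h (a higher number here means a weaker inhibitor, a lower number a stronger inhibitor), compound 1 gives > 100000 nM, which is a limit of the assay and not a number. In this assay compound 2 likewise gives > 100000 nM, again a limit. Both values therefore sit at the limit of > 100000 nM in this assay, at which 2 of the 2 values shown sit. Compound 3 `O=C(Nc1ccc(Cl)c(-c2nnc3c(Cl)cccn23)c1)c1c(F)cccc1Cl` carries 2-chloro-6-fluorophenyl in place of 4-chlorophenyl on a carbonyl carbon. Going by the values given here, with no measured step to guide this change, the expected step from compound 2 to compound 3 is a number no higher from compound 2 to compound 3 (the limit leaves the size open), nothing beyond the scatter. Compound 3 is thus expected near 100000 nM, within 20000 nM to 500000 nM.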

Compound 3, half-maximal inhibitory concentration: 57600 nM
Estimate against measurement, compound 3: 1.7-fold (0.24 log units) above; measured number inside the range.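

On these data alone, the change to 2-chloro-6-fluorophenyl on the carbonyl carbon gives an at least 1.7-fold lower number from compound 2 to compound 3 (0.23 log units; that floor lies within the scatter) in this assay and this is only a floor, so the true size of the step stays unknown. It does show that this position can move the result off the limit of the assay. Compound 3 is the only compound shown that gives a number and not a limit: the limit of > 100000 nM in this assay, at which 2 of the 3 values shown sit.

Which of the fluorine and the chlorine in compound 3 matters remains open. So does what an amine or a carboxylic acid on this ring would do.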